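Adding a methoxy group to the benzyl amide of compound 3

This account rests on a few compounds, and the source may have more. Where it says the series, first, only, none or still open, it means among the compounds named here.

Compound 3 `COc1ccccc1C(=O)Nc1ccc2nc(SCC(=O)NCc3ccccc3)sc2c1` stands second highest of the three numbers measured in a functional assay on HepG2 cells (Homo sapiens) for cytotoxicity, read by MTT assay, with a stated time of 48 h (a higher number here means a weaker inhibitor, a lower number a stronger inhibitor), where compound 3 gives 8000 nM. Compound 1 `CNC(=O)CSc1nc2ccc(NC(=O)c3ccccc3OC)cc2s1` gives 18500 nM, and compound 2 `COc1ccc(CNC(=O)CSc2nc3ccc(NC(=O)c4ccc(Cl)cc4)cc3s2)cc1` gives 7400 nM; the values of compound 2 and compound 3 lie within the scatter of each other, so nothing can be said about their order. The single measured step among these compounds is a 2.3-fold lower number from compound 1 to compound 3 (0.36 log units; beyond the scatter). Compound 4 `COc1ccc(CNC(=O)CSc2nc3ccc(NC(=O)c4ccccc4OC)cc3s2)cc1` differs from compound 3 by methoxy in place of hydrogen on an aromatic carbon. For the measured compounds named here, no measured step changes this position alone. Compound 2 carries the same (4-methoxybenzyl)amino group on a different benzamide and gives a number close to that of compound 3. Going by the values given here, the only step of comparable kind, from compound 1 to compound 3, was modest, and the present change is a smaller addition, so a step no larger than the scatter is expected in this assay, with at most a slight lean toward a lower number. Compound 4 is therefore estimated at 7000 nM, with a range from 3500 nM to 14000 nM, which means a 1.1-fold lower number from compound 3 to compound 4 (0.06 log units; within the scatter) as the expected step.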

Compound 4, half-maximal inhibitory concentration: 2100 nM
Compound 4: the middle estimate sits 3.3-fold (0.52 log units) above what was measured, and the stated range ends above it.
By their numbers in this assay, from the lowest: compound 4; then compounds 2 and 3 (each within the scatter of the next); then compound 1.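

In this assay, for the compounds shown here, the change of hydrogen to methoxy on an aromatic carbon, para to a large group, can be read alone for the first time: it gives a 3.8-fold lower number from compound 3 to compound 4 (0.58 log units; beyond the scatter) and so shows that this end of the benzyl amide is not indifferent. With the (4-methoxybenzyl)amino group held in place, 2-methoxyphenyl in place of 4-chlorophenyl on the carbonyl carbon gives a 3.5-fold lower number from compound 2 to compound 4 (0.55 log units; beyond the scatter) and thus shows that the benzamide side also matters, while 4-methoxyphenyl in place of hydrogen on the saturated chain carbon gives an 8.8-fold lower number from compound 1 to compound 4 (0.94 log units; beyond the scatter) against the earlier 2.3-fold lower number from compound 1 to compound 3 (0.36 log units; beyond the scatter) for phenyl. Nothing at hand accounts for these steps.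

On these data alone, it remains open whether a hydroxy group, a chlorine atom or a longer ethoxy chain at this place would give a similar step. As far as these compounds go, it is also open whether the methoxy step keeps its size on the 4-chlorophenyl amide.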